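The source may report more compounds than this note shows. Statements on the series, on what has been measured and on what is new or still open speak of the compounds shown alone.

For the measured compounds named here, compound 2 `Cc1cc(NCc2ccccn2)n2ncc(-c3ccc(F)cc3)c2n1` is one of three compounds measured in a physicochemical assay for solubility, read by HPLC, using the shake flask method, measured as kinetic solubility, with a stated time of 2 h, at pH 7.4; a lower number here means a less soluble compound, a higher number a more soluble compound. In this assay compound 2 gives < 5000 nM, which is a limit of the assay rather than a number. Compound 1 `Cc1cc(NCc2ccccn2)n2nc(C)c(-c3ccc(F)cc3)c2n1` likewise gives < 5000 nM, again a limit. Compound 3 `Cc1cc(OCc2ccccn2)n2nc(C)c(-c3ccccc3)c2n1` gives 25600 nM. The step that the two limits leave unreadable from compound 1 to compound 2 cannot be read because both ends sit at the limit (the limit of < 5000 nM in this assay, at which 2 of the 3 values shown sit). The change now considered is 2,6-dimethylphenyl in place of 4-fluorophenyl on an aromatic carbon, which gives compound 4 `Cc1cc(NCc2ccccn2)n2ncc(-c3c(C)cccc3C)c2n1`. Going by the values given here, no measured step bears on this change, and the limit leaves the true position of compound 2 unknown. The step that the limit leaves unreadable from compound 2 to compound 4 is expected to be small. Compound 4 is therefore expected near 3000 nM, in a range from 800 nM to 12000 nM.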

Compound 4, solubility: < 5000 nM
Compound 4: a limit, no number (the forecaster's own chance of this, stated with the estimate: 65%); the middle value does not contradict the limit.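

Compound 2 and compound 4 both sit at a limit rather than at a number, so no step can be read between them: the limit of < 5000 nM in this assay, at which 3 of the 4 values shown sit. The compounds shown leave open whether 2,6-dimethylphenyl in place of 4-fluorophenyl shifts the true reading in this assay at all.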